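Replacing the cyclopentene ester with an indazole on the shared core

This account rests on a few compounds, and the source may have more. Where it says the series, first, only, none or still open, it means among the compounds named here.

Compound 3 `COC(=O)[C@H]1C=C[C@@H](Nc2ncnc3c2nnn3[C@@H]2C[C@@H](COS(N)(=O)=O)[C@@H](O)C2)C1` gives the highest of the three numbers seen so far in an assay on a protein complex for inhibition of NEDD8 activating enzyme (Homo sapiens), read by HTRF, with a stated time of 2 h, in the presence of a further agent that is not named here (on this read-out lower numbers stand for stronger inhibition and higher numbers for weaker inhibition), with 80.9 nM. Compound 1 `NS(=O)(=O)OC[C@@H]1C[C@@H](n2nnc3c(N[C@H]4CCc5ccccc54)ncnc32)C[C@@H]1O` gives 0.21 nM and compound 2 `NS(=O)(=O)OC[C@@H]1C[C@@H](n2nnc3c(NCc4ccco4)ncnc32)C[C@@H]1O` gives 30.6 nM. Compound 4 `NS(=O)(=O)OC[C@@H]1C[C@@H](n2nnc3c(Nc4n[nH]c5ccccc45)ncnc32)C[C@@H]1O` differs from compound 3 by a group of 9 heavy atoms (7 carbon, 2 nitrogen; one five-membered aromatic ring with 2 hetero atoms, one six-membered aromatic ring of carbon only) in place of a group of 9 heavy atoms (7 carbon, 2 oxygen; one five-membered non-aromatic ring of carbon only), on a nitrogen on an aromatic ring. The step from compound 3 to compound 1 is the closest guide: that swap of the ester-bearing ring for a fused bicyclic ring gave a 390-fold higher number from compound 1 to compound 3 (2.59 log units; beyond the scatter) in the reverse direction, and the smaller furan ring gave a 2.6-fold higher number from compound 2 to compound 3 (0.42 log units; beyond the scatter). A fused aromatic bicycle therefore seems likely to bring the number down, though not fully to compound 1. The expected step is a 10-fold lower number from compound 3 to compound 4 (1.00 log units; beyond the scatter), so compound 4 is estimated at 8 nM, between 1 nM and 60 nM.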

Compound 4, half-maximal inhibitory concentration: > 10000 nM
Compound 4: a limit, no number; the forecaster's own chance of this, stated with the estimate: 2%; at least 1200-fold (3.09 log units) between middle value and limit.
By their numbers in this assay, from the lowest: compound 1; then compound 2; then compound 3. At a limit, above all of these: compound 4.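

Compound 4 reads as a limit, not a number: the limit of > 10000 nM in this assay, at which 1 of the 4 values shown sits. With 1H-indazol-3-yl on this nitrogen on an aromatic ring, the steps are an at least 120-fold higher number from compound 3 to compound 4 (2.09 log units; beyond the scatter), an at least 320-fold higher number from compound 2 to compound 4 (2.51 log units; beyond the scatter) and an at least 47000-fold higher number from compound 1 to compound 4 (4.67 log units; beyond the scatter). A group's heavy-atom count alone therefore does not set the number here: 2,3-dihydro-1H-inden-1-yl and 1H-indazol-3-yl both have 9 heavy atoms and a six-membered aromatic ring, yet compound 1 and compound 4 sit at opposite ends of the series. From the compounds shown here alone, it remains open whether the loss follows the aromatic ring joined directly to this nitrogen or the two ring nitrogens of the indazole. A phenyl or a 1H-indol-3-yl group here would separate those two readings.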